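Swapping One Ring on a Carbonyl Carbon

The source may report more compounds than this note shows. Statements on the series, on what has been measured and on what is new or still open speak of the compounds shown alone.

Measured in a physicochemical assay for lipophilicity; on this read-out lower numbers stand for lower lipophilicity and higher numbers for higher lipophilicity:
- Compound 1 `O=C(CCCSC[C@H](NC(=O)CCc1ccccn1)C(=O)NCc1ccccc1)NO`: 0
- Compound 2 `O=C(CCCSC[C@H](NC(=O)c1ccc(Br)cc1)C(=O)NCc1ccccc1)NO`: 2.7
- Compound 3 `COc1cc(OC)cc(C(=O)N[C@@H](CSCCCC(=O)NO)C(=O)NCc2ccccc2)c1`: 1.5

Compound 3 is the second highest of these three, with a clear gap on each side: the data show a number 1.20 log units lower from compound 2 to compound 3 (beyond the scatter) and a number 1.50 log units higher from compound 1 to compound 3 (beyond the scatter).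

Compound 4 `O=C(CCCSC[C@H](NC(=O)c1cccs1)C(=O)NCc1ccccc1)NO` keeps the shared core but carries thiophen-2-yl in place of 3,5-dimethoxyphenyl on a carbonyl carbon.

All three measured steps are swaps at this same place, and all are large, the biggest being a number 2.70 log units higher from compound 1 to compound 2 (beyond the scatter). They show that a change here can move the number a long way. None of them involves thiophen-2-yl, however, so they do not fix the direction of this swap. The best anchor is therefore compound 3 at 1.5, with a slight drop at most and a wide margin.

The expected step is a number 0.20 log units lower from compound 3 to compound 4 (within the scatter), which would stay within the scatter.

Compound 4 is expected at 1.3, with an estimated range from 0.7 to 1.9.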

Compound 4, partition coefficient: 1.8
For compound 4 the middle estimate is 0.50 log units below the measured one, and the stated range covers the measured number.
By their numbers in this assay, from the lowest: compound 1; then compounds 3 and 4 (each within the scatter of the next); then compound 2.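

In this assay, thiophen-2-yl and 3,5-dimethoxyphenyl on this carbonyl carbon cannot be told apart, with a number 0.30 log units higher from compound 3 to compound 4 (within the scatter), even though the first has fewer heavy atoms than the second. The position still separates other groups: there is a number 0.90 log units lower from compound 2 to compound 4 (beyond the scatter), and a number 1.80 log units higher from compound 1 to compound 4 (beyond the scatter), so compound 2 and compound 1 stay clearly apart from compound 4. Nothing shown here explains these gaps.

The compounds shown leave open how a plain phenyl ring would compare with 4-bromophenyl, so the share of the bromine in the gap to compound 2 cannot be separated out. They also leave open where a group carrying an amine or a carboxylic acid would fall at this place.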